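Oxazole substituent change on the shared core: vinyl for hydrogen

The compounds below may be only part of what the source reports. "The series", "measured", "known", "first", "only" and "open" are said of these compounds alone.

Measured compounds:
- compound 1, `c1ccc2c(-c3coc(-c4ccncc4)n3)c[nH]c2c1`, 105000 nM
- compound 2, `c1ccc2c(-c3cocn3)c[nH]c2c1`, 103000 nM

Both values come from a functional assay on MDA-MB-231 cells (Homo sapiens) for cytotoxicity, read by MTT assay, with a stated time of 48 h; on this read-out lower numbers stand for stronger inhibition and higher numbers for weaker inhibition. Compound 2 has the lowest of the two numbers, but its nearest neighbour is compound 1, and the step of a 1.0-fold lower number from compound 1 to compound 2 (0.01 log units; within the scatter) lies within the scatter, so the two compounds cannot be told apart on this read-out.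

Compound 3, `C=Cc1nc(-c2c[nH]c3ccccc23)co1`, is not yet measured. It differs from compound 2 by vinyl in place of hydrogen on an aromatic carbon.

For the measured compounds named here, the only measured step that bears on this change is the one from compound 1 to compound 2, in which a pyridin-4-yl at the same aromatic carbon gave way to hydrogen; that step was a 1.0-fold lower number from compound 1 to compound 2 (0.01 log units; within the scatter). A group of the size of a pyridin-4-yl made no difference beyond the scatter at this carbon, so the smaller vinyl is expected to leave the number where it is: the expected step is a 1.0-fold lower number from compound 2 to compound 3 (0.01 log units; within the scatter), no direction beyond the scatter.

For compound 3 the estimate in this assay is 100000 nM, with a range from 40000 nM to 250000 nM.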

Compound 3, half-maximal inhibitory concentration: 103000 nM
The estimate for compound 3 lay 1.0-fold (0.01 log units) below the measured number, and the stated range covers the measured number.
By their numbers in this assay, from the lowest: compounds 2, 3 and 1 (each within the scatter of the next).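

At the aromatic carbon next to the ring nitrogen and next to the ring oxygen, a group with no ring and one double bond now stands beside hydrogen and pyridin-4-yl as a third substituent, and in this assay vinyl in place of hydrogen gives no change at the digits printed from compound 2 to compound 3 (within the scatter). Vinyl in place of pyridin-4-yl gives a 1.0-fold lower number from compound 1 to compound 3 (0.01 log units; within the scatter), so the flat picture at this carbon no longer rests on a single pair: the three substituents, with or without a ring, cannot be told apart on this read-out. Nothing on hand offers a reason for this flat result.

On these data alone, whether an amine, a carboxylic acid or a longer alkyl chain at this carbon would move the number away from the level of compound 3 at 103000 nM stays open. Also open is whether a chlorine or a methoxy group elsewhere on the shared core would change the number; the three compounds shown vary at this one carbon only.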